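The source may report more compounds than this note shows. Statements on the series, on what has been measured and on what is new or still open speak of the compounds shown alone.

Values measured so far in a physicochemical assay for lipophilicity (a lower number here means a more polar compound, a higher number a more lipophilic compound), are as follows
- compound 1 `CCCC(=O)OC[C@H]1C[C@]2(OC(=O)/C=C/c3ccccc3)C(=O)/C(C)=C/[C@@H]3[C@H](CC[C@@]4(C)O[C@@H]4[C@H]2[C@H]1OC(=O)CCC)C3(C)C` gives 8
- compound 2 `CC(=O)OC[C@H]1C[C@]2(OC(=O)/C=C/c3ccccc3)C(=O)/C(C)=C/[C@@H]3[C@H](CC[C@@]4(C)O[C@@H]4[C@H]2[C@H]1O)C3(C)C` gives 5.5
- compound 3 `CC1(C)[C@@H]2/C=C(\CO)C(=O)[C@@]3(OC(=O)/C=C/c4ccccc4)C[C@H](COC(=O)c4ccccc4)[C@H](O)[C@@H]3[C@H]3O[C@]3(C)CC[C@@H]21` gives 5.9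

Compound 2 has the lowest number of the three. Compound 3 lies nearest to it, and even that gap goes beyond the usual scatter of repeated measurements. Compound 1 lies furthest away, also beyond the scatter. These three compounds differ from one another in more than one place, so their values do not show what any single structural change does.

Compound 4 `C/C1=C\[C@@H]2[C@H](CC[C@@]3(C)O[C@@H]3[C@H]3[C@@H](O)[C@@H](C)C[C@]3(OC(=O)/C=C/c3ccccc3)C1=O)C2(C)C` has not been measured yet. It differs from compound 2 in one place only: hydrogen in place of acetoxy on a saturated chain carbon bound to a saturated ring carbon. Cut one bond further out, the same difference reads acetoxymethyl to methyl.

Among the measured compounds shown here, no measured pair shows this change directly, so the expectation rests on the structural change alone. A modest rise in this assay is expected, probably a little beyond the scatter. The estimate is an expected step of a number 0.50 log units higher from compound 2 to compound 4 (beyond the scatter) in the upward direction. For compound 4 the expected value is 6 with an estimated range from 5.4 to 6.6 on this scale.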

Compound 4, partition coefficient: 5.8
Compound 4: the middle estimate sits 0.20 log units above what was measured; the range from low to high includes it.
By their numbers in this assay, from the lowest: compounds 2, 4 and 3 (each within the scatter of the next, the first and the last beyond it); then compound 1.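

Among the compounds shown here, compound 2 and compound 4 form the first pair here that differs in one place only, so a single structural change can finally be read on its own. In this assay, putting hydrogen in place of acetoxy on a saturated chain carbon bound to a saturated ring carbon, which turns acetoxymethyl into methyl, gives a number 0.30 log units higher from compound 2 to compound 4 (within the scatter), so at this position a group of four heavy atoms, with two hydrogen-bond acceptors, can be removed while the two numbers stay within the usual scatter of repeated measurements. Nothing else shown bears on why the two values lie so close together.

This is one pair, carrying only acetoxy and hydrogen at this place on one shared core, so it cannot say whether the same swap would give a similar result in another part of the molecule or on a different core. It also leaves open where this assay would place compounds that differ from compound 4 only by an amine, a carboxylic acid or a longer alkyl chain on this same carbon.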